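Sulfanylmethyl in place of sec-butyl: working notes

The source may hold more compounds than are shown below. What is called first, only, known or untested is meant among the compounds shown, and "the series" means these compounds.

Measured so far in a functional assay on HepG2 cells (Homo sapiens) for inhibition, read by MTT assay, with a stated time of 3 days (on this read-out higher numbers stand for weaker inhibition and lower numbers for stronger inhibition), for two compounds:
- compound 1 `COc1cc(-c2nc3ccccc3s2)ccc1OCC(=O)NNC(=O)CCl` gives 2890 nM
- compound 2 `CCOC(=O)[C@@H](NCC(=O)NNC(=O)COc1ccc(-c2nc3ccccc3s2)cc1OC)[C@@H](C)CC` gives 3460 nM

Compound 2, at 3460 nM in this assay, stands level with compound 1 within the scatter. Among the measured compounds shown here, the one measured step is a 1.2-fold higher number from compound 1 to compound 2 (0.08 log units; within the scatter) and it introduced the whole (1-(ethoxycarbonyl)-2-methylbutyl)amino group in place of chloro. Compound 3 `CCOC(=O)[C@H](CS)NCC(=O)NNC(=O)COc1ccc(-c2nc3ccccc3s2)cc1OC` is not yet measured. It differs from compound 2 at one place (sulfanylmethyl in place of sec-butyl on a saturated chain carbon bound to an amine nitrogen and a carbonyl carbon), with sulfanylmethyl in place of sec-butyl on a saturated chain carbon bound to an amine nitrogen and a carbonyl carbon. For the measured compounds named here, no measured step isolates this exchange, so the small step of a 1.2-fold higher number from compound 1 to compound 2 (0.08 log units; within the scatter) is the only guide. In this assay no change beyond the scatter is therefore expected, and the estimated step is a 1.2-fold lower number from compound 2 to compound 3 (0.06 log units; within the scatter) in either direction. For compound 3 the estimate is 3000 nM with an expected range from 1200 nM to 7500 nM overall.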

Compound 3, half-maximal inhibitory concentration: 3760 nM
Estimate against measurement, compound 3: 1.3-fold (0.10 log units) below, within the range that was stated.
By their numbers in this assay, from the lowest: compounds 1, 2 and 3 (each within the scatter of the next).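

In this assay, among the compounds shown here, sulfanylmethyl in place of sec-butyl on the saturated chain carbon bound to an amine nitrogen and a carbonyl carbon gives a 1.1-fold higher number from compound 2 to compound 3 (0.04 log units; within the scatter), the first measured exchange at this position, and compound 3 stands level with compound 2 within the scatter. Set against the chloro compound, the (1-(ethoxycarbonyl)-2-sulfanylethyl)amino group gives a 1.3-fold higher number from compound 1 to compound 3 (0.11 log units; within the scatter), so a second amino ester side chain in place of chloro also stays level with compound 1 within the scatter. Nothing available explains why these compounds stand level.

Going by these compounds, it remains open whether a carboxylic acid in place of the ethoxycarbonyl group would stay level with compound 2 and compound 3. The series shown also gives no reading for hydroxymethyl, benzyl or a longer chain at this position.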